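Propyl to Butyl on the Shared Core: an Expected Step

The compounds below may be only part of what the source reports. "The series", "measured", "known", "first", "only" and "open" are said of these compounds alone.

Compound 1 `CCn1c(=O)[nH]c2c(cnn2-c2cccc(Cl)c2)c1=N`: 19800 nM
Compound 2 `CCCn1c(=O)[nH]c2c(cnn2-c2cccc(Cl)c2)c1=N`: 14600 nM

Of the compounds shown here, two have been measured in an assay on membranes from brain for binding affinity to adenosine receptor A1 (Rattus norvegicus); on this read-out lower numbers stand for stronger inhibition and higher numbers for weaker inhibition. Compound 1 has the structure `CCn1c(=O)[nH]c2c(cnn2-c2cccc(Cl)c2)c1=N` and gives 19800 nM. Compound 2, with the structure `CCCn1c(=O)[nH]c2c(cnn2-c2cccc(Cl)c2)c1=N`, gives 14600 nM. Going by the values given here, the single step between them, a 1.4-fold lower number from compound 1 to compound 2 (0.13 log units; within the scatter), falls within the scatter, so the two numbers cannot be told apart; compound 2 simply holds one of two closely placed values.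

Compound 3 `CCCCn1c(=O)[nH]c2c(cnn2-c2cccc(Cl)c2)c1=N` has not been measured. It differs from compound 2 by methyl in place of hydrogen on a saturated chain carbon, three bonds along the chain from an aromatic nitrogen, the same kind of change that separates compound 1 from compound 2. Because a 1.4-fold lower number from compound 1 to compound 2 (0.13 log units; within the scatter) was within the scatter, a similar outcome is expected here: a step of a 1.2-fold lower number from compound 2 to compound 3 (0.09 log units; within the scatter) that stays close to compound 2 rather than moving clearly in either direction. Compound 3 is therefore estimated at 12000 nM, within a range from 5500 nM to 26000 nM.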

Compound 3, half-maximal inhibitory concentration: 6400 nM
Compound 3: middle estimate off by 1.9-fold (0.27 log units), on the high side, within the range that was stated.
By their numbers in this assay, from the lowest: compound 3; then compounds 2 and 1 (each within the scatter of the next).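

In this assay, going from propyl to butyl gives a 2.3-fold lower number from compound 2 to compound 3 (0.36 log units; beyond the scatter), so this one added carbon has a readable effect, whereas the step from ethyl to propyl stayed within the scatter. Across the full change from ethyl to butyl, the result is a 3.1-fold lower number from compound 1 to compound 3 (0.49 log units; beyond the scatter), which shows that the number at this position responds to chain length, though only modestly over the three chains shown. No measurement at hand explains why the difference becomes readable at butyl.

As far as these compounds go, it remains open whether a longer chain such as pentyl or hexyl would lower the number further or reverse the direction. Also open, from the compounds shown here alone, is how a branched chain such as isobutyl, or a butyl chain ending in an amine or a carboxylic acid, would compare with butyl.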